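A few compounds are considered here, and "the series" means these few. Any claim that something is new, unique, unknown or untested is made for them only; others in the source may bear on it.

Measured compounds: compound 1 `COc1cccc(CNCCCCCCNCCCCCCNCCCCCCNCc2ccccc2OC)c1`, 6.01; compound 2 `COc1cc2nc(N3CCN(C(=O)c4ccccc4C(F)(F)F)CC3)nc(N)c2cc1OC`, 6.55; compound 3 `COc1cc2nc(N3CCN(C(=O)c4cccc(C(F)(F)F)c4)CC3)nc(N)c2cc1OC`, 7.16.

In a functional assay on spleen for antagonist activity at Alpha-1B adrenergic receptor (Rattus norvegicus) (a higher number here means a more potent compound, by a factor of ten per unit of this negative logarithm, a lower number a less potent compound), compound 3 gives 7.16, the highest of the three numbers. Its nearest neighbour is compound 2, which in this assay gives 6.55, a gap beyond the scatter; the furthest is compound 1, which in this assay gives 6.01, also beyond the scatter.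

Compound 4 `COc1cc2nc(N3CCN(C(=O)c4ccc(C(F)(F)F)cc4)CC3)nc(N)c2cc1OC` has not yet been measured. It differs from compound 3 by 4-(trifluoromethyl)phenyl in place of 3-(trifluoromethyl)phenyl on a carbonyl carbon. Among the compounds with values here, the only measured step that bears on this change is the one within the same shared core, a number 0.61 log units higher from compound 2 to compound 3 (beyond the scatter), which moved the trifluoromethyl group from one position on the phenyl ring to another and gave a modest gain. Nothing here shows what a further move of the same group does, and the step from compound 2 to compound 3 cannot be read as a trend toward compound 4. A step close to none beyond the scatter is therefore expected in this assay, written as a number 0.16 log units lower from compound 3 to compound 4 (within the scatter). For compound 4 the estimated value in this assay is 7, with a range from 6.3 to 7.7.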

Compound 4, negative logarithm of the antagonist equilibrium constant: 7.45
Compound 4: the middle estimate sits 0.45 log units below what was measured; low and high end bracket the measured number.
By their numbers in this assay, from the lowest: compound 1; then compound 2; then compounds 3 and 4 (each within the scatter of the next).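

In this assay, 4-(trifluoromethyl)phenyl in place of 3-(trifluoromethyl)phenyl on a carbonyl carbon comes to a number 0.29 log units higher from compound 3 to compound 4 (within the scatter), so moving the trifluoromethyl group once more brings no readable difference on the shared core. Starting instead from the 2-(trifluoromethyl)phenyl amide, the 4-(trifluoromethyl)phenyl group gives a number 0.90 log units higher from compound 2 to compound 4 (beyond the scatter); together with the earlier a number 0.61 log units higher from compound 2 to compound 3 (beyond the scatter), this sets the 2-(trifluoromethyl)phenyl group apart from both of the other two, which stay together, and the earlier gain no longer stands as a single step. Nothing available explains why the three arrangements of this group fall out in this way.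

The compounds shown leave open whether a chlorine atom, a methoxy group or a nitrile in place of the trifluoromethyl group would separate in the same way, and how a plain phenyl on that carbonyl carbon would compare with all three. They also leave open whether a longer chain or a saturated cyclohexyl ring in place of the phenyl would keep the numbers of compound 3 and compound 4.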